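This account rests on a few compounds, and the source may have more. Where it says the series, first, only, none or still open, it means among the compounds named here.

Compound 1 `CCCCOC(=O)c1cccc(NC(=O)c2cccc(-c3cc(C(=O)Nc4ccncc4F)ccc3CN)c2)c1` — 27 nM
Compound 2 `NCc1ccc(C(=O)Nc2ccncc2F)cc1-c1cccc(C(=O)Nc2cccc(CC(=O)O)c2)c1` — 1.5 nM
Compound 3 `CC(C)OC(=O)c1cccc(NC(=O)c2cccc(-c3cc(C(=O)Nc4ccncc4F)ccc3CN)c2)c1` — 7 nM

All three compounds share one core and were tested in an assay on cells for inhibition of Rho-associated protein kinase 2 (Homo sapiens), read by radiometric assay and 33P incorporation, in the presence of a further agent that is not named here; a higher number here means a weaker inhibitor, a lower number a stronger inhibitor. Compound 3 stands second highest of the three numbers: compound 1 lies above it, a 4.7-fold higher number from compound 2 to compound 3 (0.67 log units; beyond the scatter), while compound 2 lies below it, a 3.9-fold lower number from compound 1 to compound 3 (0.59 log units; beyond the scatter) shows the gap in the other direction.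

Compound 4 `CCC(C)OC(=O)c1cccc(NC(=O)c2cccc(-c3cc(C(=O)Nc4ccncc4F)ccc3CN)c2)c1` is not yet measured. It differs from compound 3 in one place: methyl in place of hydrogen on a saturated chain carbon, two bonds along the chain from an oxygen next to a carbonyl group. The ester group thus grows from isopropyl to sec-butyl.

Among the compounds with values here, only one measured step bears on this kind of change: a 3.9-fold lower number from compound 1 to compound 3 (0.59 log units; beyond the scatter), where a butyl ester was shortened to an isopropyl ester and the number fell modestly. Growing the ester again, though only by one carbon and on a branched chain, would by that step be expected to push the number back up somewhat. The step of an 18-fold lower number from compound 1 to compound 2 (1.26 log units; beyond the scatter) concerns a different group and does not speak to this change.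

Compound 4 is therefore expected to give a modestly higher number than compound 3, a 1.7-fold higher number from compound 3 to compound 4 (0.23 log units; within the scatter), estimated at 12 nM with a range from 5 nM to 30 nM.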

Compound 4, half-maximal inhibitory concentration: 2.6 nM
Compound 4: middle estimate off by 4.6-fold (0.66 log units), on the high side; measured number outside the range, below it.
By their numbers in this assay, from the lowest: compounds 2 and 4 (each within the scatter of the next); then compound 3; then compound 1.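

Adding one methyl to the isopropyl ester gives a lower number, not a higher one (a 2.7-fold lower number from compound 3 to compound 4 (0.43 log units; beyond the scatter)), so the earlier drop from butyl to isopropyl cannot be read as shorter esters simply doing better. Among these esters, how the chain is arranged matters as well as its size: sec-butyl in place of butyl brings a large drop (a 10-fold lower number from compound 1 to compound 4 (1.02 log units; beyond the scatter)), and the sec-butyl ester cannot be told apart from the carboxymethyl compound (a 1.7-fold higher number from compound 2 to compound 4 (0.24 log units; within the scatter)). No measurement shown here explains why the added methyl lowers the number.

As far as these compounds go, whether a tert-butyl ester or a longer branched chain would lower the number further remains open. So does how an amide in place of the ester would compare with these compounds.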